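This account rests on a few compounds, and the source may have more. Where it says the series, first, only, none or still open, it means among the compounds named here.

Measured compounds:
- compound 1 `Cc1noc(C)c1COC1CC(=O)Nc2c1c(C)nn2-c1ncnc2nc[nH]c12`: in a functional assay on HEK293 cells for agonist activity at G-protein coupled receptor 39 (Homo sapiens), read by scintillation proximity assay and inositol phosphate accumulation, with a stated time of 75 min, in the presence of a further agent that is not named here (on this read-out lower numbers stand for an effect already at smaller amounts and higher numbers for an effect only at larger amounts of compound), compound 1 gives 5 nM
- compound 2 `CCC(C(=O)NC1CC(=O)Nc2c1c(C)nn2-c1ncnc2nc[nH]c12)c1ccccc1`: compound 2 gives 5 nM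
- compound 3 `Cc1nn(-c2ncnc3nc[nH]c23)c2c1C(OCc1ccc(Cl)cc1Cl)CC(=O)N2`: compound 3 gives 4 nM

Compound 3 holds the lowest of the three numbers, but compound 1 and compound 2 both sit within the scatter of it, so no order among the three can be read. Going by the values given here, the one measured step, a 1.3-fold lower number from compound 1 to compound 3 (0.10 log units; within the scatter), lay within the scatter. Compound 4 `Cc1nn(-c2ncnc3nc[nH]c23)c2c1C(NC(=O)Cc1cccs1)CC(=O)N2` alters compound 3 by (((thiophen-2-yl)methyl)carbonyl)amino in place of (2,4-dichlorobenzyl)oxy on a saturated ring carbon. Among the compounds with values here, no measured step covers this change; the step to compound 3 concerns only the aryl part of the chain. Within the data shown here, compound 2 differs from compound 3 in more than one place, so no step is given; its value and that of compound 3 lie within the scatter of each other. The step is therefore expected to be a 2.0-fold higher number from compound 3 to compound 4 (0.30 log units; within the scatter), not beyond the scatter. Compound 4 is estimated at 8 nM, range 2 nM to 30 nM.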

Compound 4, half-maximal effective concentration: 3 nM
For compound 4 the middle estimate is 2.7-fold (0.43 log units) above the measured one, within the range that was stated.
By their numbers in this assay, from the lowest: compounds 4, 3, 1 and 2 (each within the scatter of the next).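

At the saturated ring carbon, (((thiophen-2-yl)methyl)carbonyl)amino can stand in place of either oxygen-bound chain in this assay without a step beyond the scatter (a 1.3-fold lower number from compound 3 to compound 4 (0.12 log units; within the scatter); a 1.7-fold lower number from compound 1 to compound 4 (0.22 log units; within the scatter)). On the carbonyl carbon, (thiophen-2-yl)methyl in place of 1-phenylpropyl also stays within it (a 1.7-fold lower number from compound 2 to compound 4 (0.22 log units; within the scatter)). This position therefore accepts chains bound through oxygen or nitrogen, with either aromatic ring type shown, without a readable change, and no measurement bearing on a reason is available. On these data alone, what a primary amine or a carboxylic acid on this carbon would do remains open, as does whether any group here moves the number beyond the scatter.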